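Swapping cyano for methyl on selenium, second time

This account rests on a few compounds, and the source may have more. Where it says the series, first, only, none or still open, it means among the compounds named here.

Measured compounds:
compound 1 `COc1ccc(N(C)c2nc(C)nc3ccccc23)cc1[Se]C`: 17 nM
compound 2 `Cc1nc(N(C)c2ccc([Se]C#N)c(Cl)c2)c2ccccc2n1`: 12 nM
compound 3 `COc1ccc(N(C)c2nc(C)nc3ccccc23)cc1[Se]C#N`: 59 nM

All three were tested in a functional assay on HepG2 cells (Homo sapiens) for inhibition, read by MTT assay, with a stated time of 48 h; on this read-out higher numbers stand for weaker inhibition and lower numbers for stronger inhibition. Compound 3 and compound 1 differ in one place: methyl in place of cyano on a selenium. That change gave a 3.5-fold lower number from compound 3 to compound 1 (0.54 log units; beyond the scatter). Compound 2 differs from compound 3 in more than one place, and the difference between the two cores is not broken down here. Compound 2 gives the lowest of the three numbers, though its value sits within the scatter of compound 1, so no order between those two can be claimed.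

Compound 4 `C[Se]c1ccc(N(C)c2nc(C)nc3ccccc23)cc1Cl` has not yet been tested. It stands to compound 2 as compound 1 stands to compound 3: methyl in place of cyano on a selenium. The place is the same in both pairs, so this is the same change. If it works as before, the step from compound 2 to compound 4 is expected to be about a 2.4-fold lower number from compound 2 to compound 4 (0.38 log units; beyond the scatter), resting on the single earlier step of a 3.5-fold lower number from compound 3 to compound 1 (0.54 log units; beyond the scatter). That earlier step is one instance only, on a different core, so the range is kept wide. For compound 4 in this assay the expected value is 5 nM, between 2 nM and 14 nM.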

Compound 4, half-maximal inhibitory concentration: 4 nM
Compound 4: the middle estimate sits 1.3-fold (0.10 log units) above what was measured; low and high end bracket the measured number.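

Putting methyl in place of cyano on the selenium of the second core gave, in this assay, a 3.0-fold lower number from compound 2 to compound 4 (0.48 log units; beyond the scatter). Set beside the earlier case, the change looks much the same on both cores: the same change on two cores in this assay, a 3.5-fold lower number (0.54 log units; beyond the scatter) from compound 3 to compound 1 and a 3.0-fold lower number (0.48 log units; beyond the scatter) from compound 2 to compound 4, 1.2-fold (0.06 log units) apart, within the scatter of two such steps. For these two pairs, then, the size of the step carried over from one core to the other, but two pairs are a small sample, and they show neither why the number falls nor whether the same step would appear on any further core in the series.

The compounds shown carry only methyl or cyano on the selenium, so they leave open what a longer chain such as ethyl, or a larger group such as benzyl, would do in that place. They also leave open whether a core bearing an amine or a carboxylic acid would answer the same swap with a step of similar size.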